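Acylhydrazone aryl exchange in a fluorophenoxy-pyridine series

The source may hold more compounds than are shown below. What is called first, only, known or untested is meant among the compounds shown, and "the series" means these compounds.

Of the compounds shown here, two of the shared core have been measured: compound 1 `CN(C)CCn1cnnc1-c1cc(Oc2ccc(NC(=O)N/N=C/c3cc(C(C)(C)C)cc(C(C)(C)C)c3O)cc2F)ccn1` and compound 2 `CN(C)CCn1cnnc1-c1cc(Oc2ccc(NC(=O)N/N=C/c3c(O)ccc4ccccc34)cc2F)ccn1`. In a functional assay on HT-29 cells (Homo sapiens) for cytotoxicity, read by MTT assay, with a stated time of 72 h (on this read-out higher numbers stand for weaker inhibition and lower numbers for stronger inhibition), compound 1 gives 680 nM, and compound 2 gives 670 nM; the two numbers lie within the scatter of each other, so neither stands apart on this read-out. Compound 3 `CN(C)CCn1cnnc1-c1cc(Oc2ccc(NC(=O)N/N=C/c3ccc(Cl)cc3Cl)cc2F)ccn1` is not yet measured. It differs from compound 2 in one place: 2,4-dichlorophenyl in place of 2-hydroxynaphthalen-1-yl on a carbon with a double bond to nitrogen. Because compound 2 gives 670 nM with a hydrogen-bond donor and acceptor that compound 3 lacks, a modest step toward a higher number, a 1.8-fold higher number from compound 2 to compound 3 (0.25 log units; within the scatter), is expected. Compound 3 is estimated at 1200 nM, in the range 400 nM to 4000 nM.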

Compound 3, half-maximal inhibitory concentration: 390 nM
Compound 3: the middle estimate sits 3.1-fold (0.49 log units) above what was measured; the whole stated range lies above it.
By their numbers in this assay, from the lowest: compounds 3, 2 and 1 (each within the scatter of the next).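

At the carbon with a double bond to nitrogen, 2,4-dichlorophenyl can take the place of 2-hydroxynaphthalen-1-yl: in this assay the exchange gives a 1.7-fold lower number from compound 2 to compound 3 (0.24 log units; within the scatter) and so does not separate the two groups. Compound 3 thus holds a value in this range without the hydrogen-bond donor, the hydrogen-bond acceptor or the second aromatic ring of the group it replaces. No measurement at hand bears on why the two groups read alike.

Still open, going by these compounds, is whether a phenyl carrying an amine or a carboxylic acid would also read within the scatter of compound 3. Also open, on these data alone, is whether a single chlorine on the phenyl would do the same.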